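A few compounds are considered here, and "the series" means these few. Any claim that something is new, unique, unknown or untested is made for them only; others in the source may bear on it.

Compound 1, `Cc1c(O)ccc2c1[C@H](Cn1cc(-c3ccc(F)cc3)nn1)[C@@]13CC(=O)[C@@](C)(CC[C@@H]21)C3`: in a functional assay on HL-60 cells (Homo sapiens) for cytotoxicity, read by MTT assay, with a stated time of 4 days (a higher number here means a weaker inhibitor, a lower number a stronger inhibitor), compound 1 gives > 20000 nM, a limit of the assay and not a number.
Compound 2, `Cc1ccc(S(=O)(=O)Oc2ccc3c(c2C)[C@H](Cn2cc(-c4ccccn4)nn2)[C@@]24CC(=O)[C@@](C)(CC[C@@H]32)C4)cc1`: in this assay compound 2 gives > 20000 nM, again a limit of the assay rather than a number.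

Going by the values given here, compound 2 thus stands at a limit, and the one further value shown is a limit as well, so no order between the two can be read; both simply sit at the limit of > 20000 nM in this assay, at which 2 of the 2 values shown sit. Compound 3, `Cc1c(O)ccc2c1[C@H](Cn1cc(-c3ccccn3)nn1)[C@@]13CC(=O)[C@@](C)(CC[C@@H]21)C3`, has not yet been measured in this assay. It differs from compound 2 by hydrogen in place of (4-methylphenyl)sulfonyl on an oxygen on an aromatic ring. Among the compounds with values here, no measured step covers this change. Compound 1, which also carries the hydroxy group, gives > 20000 nM in this assay, a limit. On that basis compound 3 is expected to remain at the limit, with no step beyond the scatter. The estimate for compound 3 in this assay is 30000 nM, ranging from 8000 nM to 100000 nM, which means an expected step that the limit leaves unreadable from compound 2 to compound 3.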

Compound 3, half-maximal inhibitory concentration: > 20000 nM
Compound 3: a limit, no number; the forecaster's own chance of this, stated with the estimate: 80%; the middle value lies beyond the limit too.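

Compound 3 gives > 20000 nM in this assay as a limit of the assay and not a number. The steps to it from compound 2 and from compound 1 therefore cannot be read. The compounds shown leave open whether any change on the shared core gives a readable number in this assay at all.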